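This account rests on a few compounds, and the source may have more. Where it says the series, first, only, none or still open, it means among the compounds named here.

Compound 1 `CN(C)CCn1cnnc1-c1cc(Oc2ccc(NC(=O)N/N=C/c3ccc(Cl)cc3Cl)cc2F)ccn1` and compound 2 `CN(C)CCn1cnnc1-c1cc(Oc2ccc(NC(=O)N/N=C/c3c[nH]c4ccccc34)cc2F)ccn1` were measured; compound 3 `CN(C)CCn1cnnc1-c1cc(Oc2ccc(NC(=O)N/N=C/c3cccc(Cl)c3Cl)cc2F)ccn1` was not.

In a functional assay on NCI-H460 cells (Homo sapiens) for cytotoxicity, read by MTT assay, with a stated time of 72 h (a higher number here means a weaker inhibitor, a lower number a stronger inhibitor), compound 1 gives 130 nM, and in this assay compound 2 gives 1630 nM. For the measured compounds named here, compound 1 therefore carries the lowest of the two numbers, with compound 2 as its only neighbour, separated by a 13-fold higher number from compound 1 to compound 2 (1.10 log units; beyond the scatter). Compound 3 differs from compound 1 in one place: 2,3-dichlorophenyl in place of 2,4-dichlorophenyl on a carbon with a double bond to nitrogen. Going by the values given here, no measured step tests this change; the single step from compound 1 to compound 2 is a large one, but it swaps the aromatic group for a different ring type rather than moving a chlorine within the same dichlorophenyl. With nothing in the data to say how that move acts in this assay, the change is expected to leave the number within the scatter, in either direction, as a 1.4-fold higher number from compound 1 to compound 3 (0.14 log units; within the scatter). Compound 3 is thus estimated at 180 nM, within a range of 60 nM to 600 nM.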

Compound 3, half-maximal inhibitory concentration: 72 nM
Compound 3: middle estimate off by 2.5-fold (0.40 log units), on the high side; measured number inside the range.
By their numbers in this assay, from the lowest: compounds 3 and 1 (each within the scatter of the next); then compound 2.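

In this assay, placing 2,3-dichlorophenyl in place of 2,4-dichlorophenyl on the carbon with a double bond to nitrogen gives a 1.8-fold lower number from compound 1 to compound 3 (0.26 log units; within the scatter) and so does not separate these two arrangements of the two chlorines. The 2,3-dichlorophenyl group also differs clearly from 1H-indol-3-yl, with a 23-fold lower number from compound 2 to compound 3 (1.35 log units; beyond the scatter), which shows that the large gap seen with compound 1 is not confined to a single dichlorophenyl group. No evidence is available that explains either step.

The compounds shown leave open whether a plain phenyl or a phenyl carrying a single chlorine at this carbon would stay close to compound 1 and compound 3 or lie nearer compound 2. They also leave open how a pyridyl group would behave there.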